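Chain swap on the ring nitrogen in an all-limit series

The source may hold more compounds than are shown below. What is called first, only, known or untested is meant among the compounds shown, and "the series" means these compounds.

Compound 3 `C=CCn1c(N)c(C#N)c2c(N)ncnc21` is the reference point for this step. In a functional assay on KB cells (Homo sapiens) for inhibition (a higher number here means a weaker inhibitor, a lower number a stronger inhibitor), compound 3 gives > 100000 nM, which is a limit of the assay and not a number. Compound 1 `COCCOCn1c(N)c(C(N)=O)c2c(N)ncnc21` is a close relative with the same chain on the ring nitrogen that compound 4 carries; in this assay compound 1 gives > 100000 nM, again a limit. Compound 2 `COCCOCn1c(N(C)C)c(C#N)c2c(N)ncnc21` in this assay gives > 100000 nM, also a limit. Compound 3 therefore stands exactly where the whole measured set stands, at the limit of > 100000 nM in this assay, at which 3 of the 3 values shown sit, and no number exists by which the three compounds could be ordered against one another.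

Compound 4 `COCCOCn1c(N)c(C#N)c2c(N)ncnc21` has not yet been measured. It differs from compound 3 by 2-methoxyethoxy in place of vinyl on a saturated chain carbon bound to an aromatic nitrogen. Among the measured compounds shown here, no measured step is recorded for a change of this kind, so its size and direction cannot be read from the data. What the data do show is that compound 1, which already carries the entering chain, sits at the limit. The step that the limit leaves unreadable from compound 3 to compound 4 is expected to be none beyond the scatter, with a limit the most probable outcome. Compound 4 is estimated to give 200000 nM in this assay, with a range from 40000 nM to 1000000 nM.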

Compound 4, half-maximal inhibitory concentration: 210000 nM
For compound 4 the middle estimate is 1.1-fold (0.02 log units) below the measured one, and the stated range covers the measured number.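

No step to compound 4 can be read from compound 1, compound 2 or compound 3, as each gives only a limit in this assay: the limit of > 100000 nM in this assay, at which 3 of the 4 values shown sit.

The compounds shown leave open the size and direction of all three changes: allyl to (2-methoxyethoxy)methyl, dimethylamino to amino, and carbamoyl to cyano.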